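Series notes: from compound 2 toward compound 4

The source may report more compounds than this note shows. Statements on the series, on what has been measured and on what is new or still open speak of the compounds shown alone.

In an assay on isolated protein for inhibition of thyroid hormone receptor alpha (Homo sapiens), read by fluorescence polarization (a lower number here means a stronger inhibitor, a higher number a weaker inhibitor), compound 1 `CS(=O)(=O)c1ccc(C(=O)N2CCC(C(=O)N(Cc3ccccc3)Cc3ccccc3)CC2)cc1[N+](=O)[O-]` gives only a limit, > 60000 nM. Compound 2 `CC(C)N(C(=O)CCNC(=O)c1ccc(S(C)(=O)=O)c([N+](=O)[O-])c1)C(C)C` likewise gives only a limit in this assay, > 60000 nM. Compound 3 `CCCN(C(=O)CN(C)C(=O)c1ccc(S(C)(=O)=O)c([N+](=O)[O-])c1)c1ccccc1` also returns only a limit in this assay, > 60000 nM. Compound 2 therefore stands where every value shown stands, at the limit of > 60000 nM in this assay, at which 3 of the 3 values shown sit, with no number to set it apart from the others. Compound 4 `CS(=O)(=O)c1ccc(C(=O)NCCCC(=O)N2CCCCC2)cc1[N+](=O)[O-]` has not been measured. It differs from compound 2 by ((piperidin-1-yl)carbonyl)methyl in place of diisopropylcarbamoyl on a saturated chain carbon, two bonds along the chain from an amide-type nitrogen. Among the measured compounds shown here, no measured pair carries a change of this kind, so no size or direction of step can be read from the values shown. Compound 4 is expected to remain at the limit, the expected step being a number no higher from compound 2 to compound 4 (the limit leaves the size open). The estimate for compound 4 in this assay is 60000 nM, within a range from 20000 nM to 300000 nM.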

Compound 4, half-maximal inhibitory concentration: > 60000 nM
Compound 4: a limit, no number (the forecaster's own chance of this, stated with the estimate: 85%); the middle value lies on the limit itself.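

Among the compounds shown here, compound 2 and compound 4 each return only a limit, so no step between them can be read. The compounds shown leave open which change, if any, would give a measurable number.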